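Chain Extension of an Acid Side Chain in Two Cores

This account rests on a few compounds, and the source may have more. Where it says the series, first, only, none or still open, it means among the compounds named here.

Measured compounds in a physicochemical assay for lipophilicity, at pH 7.4; a lower number here means a more polar compound, a higher number a more lipophilic compound:
compound 1, `Cc1nn(-c2nnc(-c3ccc(OC(C)C)c(Cl)c3)s2)c(C)c1CC(=O)O`: 3.62
compound 2, `Cc1nn(-c2nnc(-c3ccc(OC(C)C)c(Cl)c3)s2)c(C)c1CCC(=O)O`: 4.3
compound 3, `CC(C)Oc1ccc(-c2nnc(-n3cc4c(n3)CCN(CCC(=O)O)C4)s2)cc1C#N`: 2.58

Compound 1 and compound 2 share one core; the change between them is carboxymethyl in place of carboxy on a saturated chain carbon bound to an aromatic carbon and it gave a number 0.68 log units higher from compound 1 to compound 2 (beyond the scatter). Compound 3 is built on a different core, and the difference between the two cores is not broken down here; in this assay compound 3 gives the lowest of the three numbers. Compound 4, `CC(C)Oc1ccc(-c2nnc(-n3cc4c(n3)CCN(CCCC(=O)O)C4)s2)cc1C#N`, is not yet measured. It differs from compound 3 by carboxymethyl in place of carboxy on a saturated chain carbon, two bonds along the chain from an amine nitrogen in a ring, the same kind of change as that from compound 1 to compound 2, though the place differs: there the chain carbon is bound to an aromatic carbon, here it lies two bonds along the chain from an amine nitrogen in a ring. Resting on the size of a number 0.68 log units higher from compound 1 to compound 2 (beyond the scatter), the step from compound 3 to compound 4 is expected to be a number 0.52 log units higher from compound 3 to compound 4 (beyond the scatter), somewhat smaller given the different surroundings. Compound 4 is therefore estimated at 3.1, between 2.6 and 3.6.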

Compound 4, distribution coefficient: 2.87
For compound 4 the middle estimate is 0.23 log units above the measured one, within the range that was stated.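

In this assay the change of carboxy to carboxymethyl gave a number 0.68 log units higher from compound 1 to compound 2 (beyond the scatter) on the core of compound 1, but the same change gave a number 0.29 log units higher from compound 3 to compound 4 (within the scatter) on the core of compound 3. A step that stood clear of the scatter on one core therefore did not do so on the other, and the pattern of a clear step holds only for the first pair, with the second pair going against it. With one pair on each core, and the change sitting in a different place in each, these results cannot separate the effect of the core from that of the place, and nothing available explains the outcome.

The compounds shown leave open how a 4-carboxybutyl chain would read on either core. They also leave open whether a primary amide in place of the carboxylic acid would follow the same course on both cores.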